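From an Undefined Stereocentre to S in Compound 4

This account rests on a few compounds, and the source may have more. Where it says the series, first, only, none or still open, it means among the compounds named here.

Compound 1 (`Nc1ccc(-c2cnc(N)c(-c3ccc(N)nc3)n2)cn1`): > 90% (a limit)
Compound 2 (`Nc1ncc(-c2ccc(C(=O)N3CCC(O)C3)cc2)nc1-c1ccc(C(F)(F)F)cc1`): > 90% (a limit)
Compound 3 (`N#Cc1ccc(-c2cnc(N)c(-c3ccc(N)nc3)n2)cc1`): > 90% (a limit)

In an ADME assay on microsomes from liver (Homo sapiens) for metabolic stability, read by LC-MS, using NADPH, with a stated time of 30 min, tested at 0.1 uM, in the presence of a further agent that is not named here (a lower number here means that less of the compound is left, a higher number that more of the compound is left), compound 2 gives > 90% as a limit of the assay and not as a number. It stands with the other two measured compounds (the limit of > 90% in this assay, at which 3 of the 3 values shown sit) and no order among them can be read.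

Compound 4 (`Nc1ncc(-c2ccc(C(=O)N3CC[C@H](O)C3)cc2)nc1-c1ccc(C(F)(F)F)cc1`) is the next compound to be considered (the two compounds have the same atoms and bonds; at least one stereo element is drawn with a configuration in one of them and without one in the other: 1 of 1 stereo elements differ; a stereocentre at a saturated ring carbon is drawn without a configuration in compound 2 and S in compound 4). The two compounds have the same atoms and bonds, and a stereocentre at a saturated ring carbon is drawn without a configuration in compound 2 and S in compound 4.

No measured pair shows a change of this kind in this assay and the expectation rests on the limit of compound 2 (> 90%) alone. The expected step is a step that the limit leaves unreadable from compound 2 to compound 4 and it is expected to stay within the usual scatter, in no set direction. Compound 4 is estimated at 93% (expected range 80% to 100%) and may again be reported only as a limit.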

Compound 4, percent of the compound remaining: > 90%
Compound 4 was reported as a limit; the forecaster's own chance of this, stated with the estimate: 80%; the middle value is on the limit's open side.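

In this assay, no step can be read from compound 2 to compound 4, as both compounds are reported only as limits: the limit of > 90% in this assay, at which 4 of the 4 values shown sit. The compounds shown leave open whether the S configuration drawn in compound 4 makes any difference to the percent remaining in this assay.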